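This account rests on a few compounds, and the source may have more. Where it says the series, first, only, none or still open, it means among the compounds named here.

Working notes on the series. In a functional assay on T47D cells (Homo sapiens) for inhibition, read by CCK-8 assay, with a stated time of 72 h, tested at 1 uM (on this read-out lower numbers stand for less inhibition of growth and higher numbers for more inhibition of growth at the one concentration tested), compound 1 `CN(C)C(=O)c1cc2cnc(Nc3ccc(NC(=O)C4(C(=O)Nc5cccc(O)c5)CC4)cc3)nc2n1C1CCCC1` gives 80.7%, compound 2 `CN(C)C(=O)c1cc2cnc(Nc3ccc(NC(=O)C4(C(=O)Nc5ccc(Br)cc5)CC4)cc3)nc2n1C1CCCC1` gives 21.1% and compound 3 `CN(C)C(=O)c1cc2cnc(Nc3ccc(NC(=O)C4(C(=O)Nc5ccc(Cl)cc5)CC4)cc3)nc2n1C1CCCC1` gives 22.8%. Compound 2 holds the lowest of the three numbers; compound 3 sits within the scatter of it, whereas the step of a number 59.6 percentage points lower from compound 1 to compound 2 (beyond the scatter) is beyond the scatter. Compound 4 `CN(C)C(=O)c1cc2cnc(Nc3ccc(NC(=O)C4(C(=O)Nc5ccc(F)cc5)CC4)cc3)nc2n1C1CCCC1` is not yet measured and differs from compound 2 by fluoro in place of bromo on an aromatic carbon. Among the compounds with values here, the only measured step bearing on such a halogen swap is a number 1.7 percentage points higher from compound 2 to compound 3 (within the scatter), which stayed within the scatter; the large step of a number 57.9 percentage points lower from compound 1 to compound 3 (beyond the scatter) concerns a different group and does not inform this change. For compound 4 no step beyond the scatter is therefore expected in this assay, the expected step being a number 0.9 percentage points higher from compound 2 to compound 4 (within the scatter). Compound 4 is estimated at 22%, within 8% to 40%.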

Compound 4, percent growth inhibition at one concentration: 74.7%
For compound 4 the middle estimate is 52.7 percentage points below the measured one; measured number outside the range, above it.
By their numbers in this assay, from the lowest: compounds 2 and 3 (each within the scatter of the next); then compounds 4 and 1 (each within the scatter of the next).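

At this position, para to a large group, the halogens are not interchangeable in this assay: the step is a number 53.6 percentage points higher from compound 2 to compound 4 (beyond the scatter) for fluoro in place of bromo and a number 51.9 percentage points higher from compound 3 to compound 4 (beyond the scatter) for fluoro in place of chloro, although chloro and bromo stayed within the scatter of each other. Replacing the 3-hydroxyphenyl with 4-fluorophenyl gives a number 6 percentage points lower from compound 1 to compound 4 (within the scatter) and so a high number in this series does not depend on the hydroxyl group. No measurement at hand accounts for the gap between fluoro and the other two halogens. Going by these compounds, whether an unsubstituted phenyl, or a methoxy or amino group at the same place, falls with fluoro or with chloro and bromo remains open.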